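The source may report more compounds than this note shows. Statements on the series, on what has been measured and on what is new or still open speak of the compounds shown alone.

Compound 3 `COc1ccc(S(=O)(=O)Nc2cc(Cl)cc(Cl)c2Br)cc1N1CCNCC1` gives 3.16 nM in an assay on isolated protein for binding affinity to 5-hydroxytryptamine receptor 6 (Homo sapiens); on this read-out lower numbers stand for stronger inhibition and higher numbers for weaker inhibition; this is the highest of the three numbers shown, yet compound 2 `COc1ccc(S(=O)(=O)Nc2cc(Br)cc(Br)c2Br)cc1N1CCNCC1` with 2.51 nM and compound 1 `COc1cc(Cl)c(C)cc1NS(=O)(=O)c1ccc(OC)c(N2CCNCC2)c1` with 2 nM both lie within the scatter of it. Compound 4 `COc1ccc(S(=O)(=O)Nc2cc(F)cc(F)c2Cl)cc1N1CCNCC1` differs from compound 3 by 2-chloro-3,5-difluorophenyl in place of 2-bromo-3,5-dichlorophenyl on a sulfonamide nitrogen. Going by the values given here, the only measured step that bears on an exchange of one halogen pattern for another on this sulfonamide nitrogen is a 1.3-fold higher number from compound 2 to compound 3 (0.10 log units; within the scatter), a change within the scatter. The step is therefore expected to be a 1.3-fold higher number from compound 3 to compound 4 (0.10 log units; within the scatter), at most a slight drift toward a higher number and nothing beyond the scatter. Compound 4 is accordingly estimated at 4 nM, with a range from 1.5 nM to 12 nM.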

Compound 4, inhibition constant: 31.6 nM
Compound 4: middle estimate off by 7.9-fold (0.90 log units), on the low side, and the stated range ends below it.
By their numbers in this assay, from the lowest: compounds 1, 2 and 3 (each within the scatter of the next); then compound 4.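

On the sulfonamide nitrogen, an exchange of halogens is not always neutral in this assay: 2-chloro-3,5-difluorophenyl in place of 2-bromo-3,5-dichlorophenyl gives a 10-fold higher number from compound 3 to compound 4 (1.00 log units; beyond the scatter) and so moves beyond the scatter, which the earlier exchange at this place did not do. Measured against 2,3,5-tribromophenyl, the same group gives a 13-fold higher number from compound 2 to compound 4 (1.10 log units; beyond the scatter) and thus a large step. Nothing shown explains this change.

All three halogens differ between compound 3 and compound 4, so their separate contributions remain unresolved. A 2-bromo-3,5-difluorophenyl group, or a phenyl bearing a nitrile, would help to test this position further.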